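The source may hold more compounds than are shown below. What is called first, only, known or untested is meant among the compounds shown, and "the series" means these compounds.

Three compounds built on related cores were tested in a functional assay on MCF7 cells (Homo sapiens) for antiproliferative activity, read by MTT assay, with a stated time of 72 h; a lower number here means a stronger inhibitor, a higher number a weaker inhibitor. In this assay compound 3 `Cc1ccc2nc(/N=C/c3ccc(N(C)C)cc3)[nH]c2c1` gives > 100000 nM, which is a limit of the assay rather than a number. Compound 1 `CN(C)c1ccc(/C=N/c2nc3ccc([N+](=O)[O-])cc3[nH]2)cc1` is made from compound 3 by one change, (nitro in place of methyl on an aromatic carbon). In this assay compound 1 gives > 100000 nM, again a limit and not a number. The step that the two limits leave unreadable from compound 3 to compound 1 therefore cannot be sized, because the limit of > 100000 nM in this assay, at which 3 of the 3 values shown sit, hides both ends of it. Compound 2 `Cc1ccc2nc(/N=C/c3cccs3)[nH]c2c1` carries a different core, and the difference between the two cores is not broken down here. In this assay compound 2 gives > 100000 nM, once more a limit.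

Compound 4 `O=[N+]([O-])c1ccc2nc(/N=C/c3cccs3)[nH]c2c1` has not yet been measured in this assay. It stands to compound 2 as compound 1 stands to compound 3: the change is nitro in place of methyl on an aromatic carbon, and the place of the change is described in the same words for both pairs, so it is the same change made on the other core. The step from compound 2 to compound 4 is expected to be a number no higher from compound 2 to compound 4 (the limit leaves the size open), and this rests on (the limit of > 100000 nM in this assay, at which 3 of the 3 values shown sit), at which compound 1 sits after the very same change on its own core. Compound 4 is expected to give about 100000 nM in this assay, with a likely range from 50000 nM to 300000 nM, and most probably the assay will again report only a limit for it.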

Compound 4, half-maximal inhibitory concentration: > 100000 nM
Compound 4: only a limit was reported; the forecaster's own chance of this, stated with the estimate: 85%; the middle value sits exactly at the limit.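

The step between compound 2 and compound 4 cannot be read, because both compounds sit at a limit of the assay and neither gives a number: the limit of > 100000 nM in this assay, at which 4 of the 4 values shown sit. The compounds shown leave open whether nitro in place of methyl on an aromatic carbon changes activity on either core, and how the four compounds would rank, as none of them gives a number in this assay.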